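Moving one fluorine on a triazole-linked chalcone series

The compounds below may be only part of what the source reports. "The series", "measured", "known", "first", "only" and "open" are said of these compounds alone.

Four compounds share one core, in which a benzyl group hangs from a triazole ring that is tied through an ether to a chalcone. Compound 1 `O=C(/C=C/c1ccc(OCc2cn(Cc3ccccc3F)nn2)cc1)c1ccc(Br)cc1` carries a 2-fluorobenzyl group and a bromo substituent; in a functional assay on A549 cells (Homo sapiens) for inhibition, read by MTT assay, with a stated time of 48 h, tested at 10 uM (a higher number here means more inhibition of growth at the concentration tested, a lower number less inhibition of growth), compound 1 gives 38%. Compound 2 `O=C(/C=C/c1ccc(OCc2cn(Cc3cccc(F)c3)nn2)cc1)c1ccc(Br)cc1` differs from it by 3-fluorophenyl in place of 2-fluorophenyl on a saturated chain carbon bound to an aromatic nitrogen, and in this assay compound 2 gives 37%, so that a number 1 percentage points lower from compound 1 to compound 2 (within the scatter). Compound 3 `O=C(/C=C/c1ccc(OCc2cn(Cc3ccccc3F)nn2)cc1)c1ccc([N+](=O)[O-])cc1` differs from compound 1 in its core by nitro in place of bromo on an aromatic carbon, and in this assay compound 3 gives 43%; here a number 5 percentage points higher from compound 1 to compound 3 (within the scatter). Compound 4 `O=C(/C=C/c1ccc(OCc2cn(Cc3cccc(F)c3)nn2)cc1)c1ccc([N+](=O)[O-])cc1` is not yet measured; it differs from compound 3 by 3-fluorophenyl in place of 2-fluorophenyl on a saturated chain carbon bound to an aromatic nitrogen, the same change made from compound 1 to compound 2. Because a number 1 percentage points lower from compound 1 to compound 2 (within the scatter), the expected step in this assay is a number 1 percentage points lower from compound 3 to compound 4 (within the scatter). Resting on compound 3 and on that earlier step, compound 4 is estimated to give about 42% in this assay, with a range from 32% to 52%.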

Compound 4, percent growth inhibition at one concentration: 33%
Beside the measured number, compound 4's estimate is 9 percentage points above it, within the range that was stated.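

On the core that carries nitro, the move from 2-fluorobenzyl to 3-fluorobenzyl gives, in this assay, a number 10 percentage points lower from compound 3 to compound 4 (within the scatter), and this step does not differ beyond the scatter from the one seen on the core of compound 1: the same change on two cores in this assay, a number 1 percentage points lower (within the scatter) from compound 1 to compound 2 and a number 10 percentage points lower (within the scatter) from compound 3 to compound 4, 9 percentage points apart, within the scatter of two such steps

With 3-fluorobenzyl in place, the swap of bromo for nitro gives a number 4 percentage points lower from compound 2 to compound 4 (within the scatter), and this step also agrees within the scatter with its earlier counterpart: the same change on two cores in this assay, a number 5 percentage points higher (within the scatter) from compound 1 to compound 3 and a number 4 percentage points lower (within the scatter) from compound 2 to compound 4, 9 percentage points apart, within the scatter of two such steps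

So nothing here shows either change behaving differently on the two cores, but since every step lies within the scatter, these four compounds show neither that the changes have a real effect of their own nor that such an effect carries from one core to the other.

Going by these compounds, it remains open whether an amine or a carboxylic acid in place of bromo or nitro would move the number in this assay beyond the scatter. The same question stands for a longer chain in place of the fluorobenzyl group.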